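Trading an Aromatic Arm for a Short Chain

This account rests on a few compounds, and the source may have more. Where it says the series, first, only, none or still open, it means among the compounds named here.

Of the compounds shown here, three sharing a core have been tested in an ADME assay on HepG2 cells (Homo sapiens) for cytotoxicity, read by luminescence, CellTiter-Glo and ATP content, with a stated time of 72 h; on this read-out higher numbers stand for an effect only at larger amounts of compound and lower numbers for an effect already at smaller amounts. Compound 1 `CC(C)(C)c1ccc(Oc2ccc3c(NCCCNCc4ccco4)ccnc3c2)cc1` gives 3100 nM. Compound 2 `FC(F)(F)c1ccc(-c2ccc3c(NCCCNCc4ccco4)ccnc3c2)cc1` gives 3470 nM, and compound 3 `CCC(CC)c1ccc2c(NCCCNCc3cc(F)ccc3OC)ccnc2c1` gives 7860 nM. Among these three, compound 2 holds the second highest number; its value sits so close to that of compound 1 that the two cannot be told apart within the usual scatter, while compound 3 lies beyond the scatter, clearly higher.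

Compound 4 `CC(C)CCc1ccc2c(NCCCNCc3ccco3)ccnc2c1` has not yet been measured in this assay. It differs from compound 2 in one place: isopentyl in place of 4-(trifluoromethyl)phenyl on an aromatic carbon. For the measured compounds named here, no measured pair isolates exactly this change. Going by the values given here, compound 3, at 7860 nM, is the only measured compound with a chain rather than a ring on the core, and it gave the highest of the three numbers, but it also carries a different amine end, so it offers only a loose hint. The expected step of a 1.4-fold higher number from compound 2 to compound 4 (0.16 log units; within the scatter) is therefore modest, upward, and probably not beyond the usual scatter. For compound 4 the estimated value is 5000 nM, with a range from 2000 nM to 12000 nM.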

Compound 4, half-maximal effective concentration: 11200 nM
Estimate against measurement, compound 4: 2.2-fold (0.35 log units) below; the range from low to high includes it.
By their numbers in this assay, from the lowest: compounds 1 and 2 (each within the scatter of the next); then compounds 3 and 4 (each within the scatter of the next).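

At this position, on an aromatic carbon of the shared core, replacing the ring-bearing 4-(trifluoromethyl)phenyl with the open-chain isopentyl gives a 3.2-fold higher number from compound 2 to compound 4 (0.51 log units; beyond the scatter) in this assay, so more of the compound is needed to produce the effect. For the compounds shown here, this is the first direct reading of a single change here, as the earlier compounds differ from one another in more than one place and could not isolate any one swap; it shows that the group at this position can by itself move the number beyond the usual scatter. Nothing available bears on why the number moves.

The swap changes several things at once: a six-membered aromatic ring and three fluorine atoms leave, and the group falls from 10 heavy atoms to 5, so this one step cannot show which of these differences matters. Still open, from the compounds shown here alone, is whether a plain phenyl group would fall nearer compound 2 or compound 4, and whether a longer carbon chain or a chain ending in an amine would shift the number further at this position.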